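N-Alkyl Extension on a Piperidinone Enone Scaffold

The compounds below may be only part of what the source reports. "The series", "measured", "known", "first", "only" and "open" are said of these compounds alone.

Measured compounds:
- compound 1, `CN1CCC(=O)/C(=C/c2ccc(OC3CCCC3)cc2)C1`: 10500 nM
- compound 2, `O=C1CCCC/C1=C\c1ccc(OC2CCCC2)cc1`: 71100 nM
- compound 3, `CC(=O)/C=C/c1ccc(OC2CCCC2)cc1`: 21800 nM

In a functional assay on PC-3 cells (Homo sapiens) for antiproliferative activity, read by MTT assay (a higher number here means a weaker inhibitor, a lower number a stronger inhibitor), compound 1 gives the lowest of the three numbers. Compound 3 sits beyond the scatter above it, and compound 2 furthest away, so compound 1 is the strongest inhibitor of the measured set.

Compound 4, `CCN1CCC(=O)/C(=C/c2ccc(OC3CCCC3)cc2)C1`, differs from compound 1 only by methyl in place of hydrogen on a saturated chain carbon bound to an amine nitrogen in a ring, which reads as methyl to ethyl when cut one bond further out. Going by the values given here, no measured pair in this set carries a change of this kind, so there is no direct precedent. Such a small addition on the ring amine is expected to move this assay little, probably not beyond the scatter, in either direction. Compound 4 is therefore estimated at 9000 nM, within 4000 nM to 25000 nM, a step of a 1.2-fold lower number from compound 1 to compound 4 (0.07 log units; within the scatter).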

Compound 4, half-maximal inhibitory concentration: 9100 nM
Estimate against measurement, compound 4: 1.0-fold (0.00 log units) below; measured number inside the range.
By their numbers in this assay, from the lowest: compounds 4 and 1 (each within the scatter of the next); then compound 3; then compound 2.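

In this assay, going by these compounds alone, methyl in place of hydrogen on a saturated chain carbon bound to an amine nitrogen in a ring gives a 1.2-fold lower number from compound 1 to compound 4 (0.06 log units; within the scatter) and is the first direct reading at this position. Going from methyl to ethyl on the ring amine therefore leaves the antiproliferative number unchanged within the usual scatter. No available evidence bears on this result.

One small step cannot show how far this position stays permissive. A longer chain, a benzyl group or a carboxylic acid on this nitrogen remains an open case.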